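The source may hold more compounds than are shown below. What is called first, only, known or untested is meant among the compounds shown, and "the series" means these compounds.

Compound 1, `CC(=O)N(/N=N/c1ccc([N+](=O)[O-])cc1Cl)c1ccc([N+](=O)[O-])cc1Cl`, gives 630 nM in a functional assay on HeLa cells (Homo sapiens) for cytotoxicity, read by MTT assay, with a stated time of 72 h; on this read-out higher numbers stand for weaker inhibition and lower numbers for stronger inhibition.
Compound 2, `O=C(c1ccccc1)N(/N=N/c1ccc([N+](=O)[O-])cc1Cl)c1ccc([N+](=O)[O-])cc1Cl`, gives 590 nM in this assay.

Among the compounds with values here, compound 2 and compound 1 lie within the scatter of each other: the only measured step, a 1.1-fold lower number from compound 1 to compound 2 (0.03 log units; within the scatter), swaps a methyl for a phenyl on the carbonyl carbon and leaves the read-out essentially unchanged.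

Compound 3, `O=C(c1ccccc1F)N(/N=N/c1ccc([N+](=O)[O-])cc1Cl)c1ccc([N+](=O)[O-])cc1Cl`, is the next member of the series. It differs from compound 2 by fluoro in place of hydrogen on an aromatic carbon; the same difference, cut one bond further out, reads phenyl to 2-fluorophenyl, or benzoyl to (2-fluorophenyl)carbonyl.

Within the data shown here, only one measured step bears on this change, and only loosely: the step of a 1.1-fold lower number from compound 1 to compound 2 (0.03 log units; within the scatter) also altered the group on the carbonyl carbon, yet rebuilt it far more thoroughly than a single fluoro would, and still stayed within the scatter. Nothing in the data shows this part of the molecule moving the read-out. Compound 3 is therefore expected to sit close to compound 2, with the step of a 1.0-fold higher number from compound 2 to compound 3 (0.01 log units; within the scatter) expected to stay within the scatter. Compound 3 is estimated at 600 nM, with a range from 300 nM to 1200 nM.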

Compound 3, half-maximal inhibitory concentration: 2350 nM
Compound 3: the middle estimate sits 3.9-fold (0.59 log units) below what was measured; measured number outside the range, above it.
By their numbers in this assay, from the lowest: compounds 2 and 1 (each within the scatter of the next); then compound 3.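

In this assay, the group on the carbonyl carbon turns out not to be silent: a single fluoro in place of hydrogen on an aromatic carbon, ortho to a large group, gives a 4.0-fold higher number from compound 2 to compound 3 (0.60 log units; beyond the scatter), even though the far larger exchange of methyl for phenyl had stayed within the scatter. Read from the other earlier compound, 2-fluorophenyl in place of methyl on the carbonyl carbon gives a 3.7-fold higher number from compound 1 to compound 3 (0.57 log units; beyond the scatter), so compound 3 stands apart from both compound 1 and compound 2, and the shift appears only once the fluoro is present. Nothing available here offers an explanation for this shift.

The compounds shown leave open whether the higher number is particular to fluoro or would also follow from another group on the same aromatic carbon, such as chloro, methoxy or an amine. They also leave open whether fluoro on a different carbon of that ring would move the number at all, and whether a fluoro-bearing longer chain in place of the ring would behave like compound 3.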